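Phenyl for thiophen-2-yl on the shared core

A few compounds are considered here, and "the series" means these few. Any claim that something is new, unique, unknown or untested is made for them only; others in the source may bear on it.

Measured so far in a functional assay on HeLa S3 cells (Homo sapiens) for antiproliferative activity, read by XTT assay, with a stated time of 72 h; on this read-out higher numbers stand for weaker inhibition and lower numbers for stronger inhibition
Compound 1 `CSc1ncnc2c1c(-c1ccccc1)cn2[C@@H]1O[C@H](CO)[C@@H](O)[C@H]1O` gives > 20000 nM as a limit
Compound 2 `CNc1ncnc2c1c(-c1ccco1)cn2[C@@H]1O[C@H](CO)[C@@H](O)[C@H]1O` gives 5000 nM
Compound 3 `CNc1ncnc2c1c(-c1cccs1)cn2[C@@H]1O[C@H](CO)[C@@H](O)[C@H]1O` gives > 20000 nM as a limit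

Compound 3 has no number, only a limit. It sits at the limit of > 20000 nM in this assay, at which 2 of the 3 values shown sit. Compound 4 `CNc1ncnc2c1c(-c1ccccc1)cn2[C@@H]1O[C@H](CO)[C@@H](O)[C@H]1O` carries phenyl in place of thiophen-2-yl on an aromatic carbon. Among the compounds with values here, the one measured step at this carbon is an at least 4.0-fold higher number from compound 2 to compound 3 (0.60 log units; beyond the scatter) and it ends at the limit. Compound 1, also bearing phenyl, reports only a limit of > 20000 nM. No step beyond the scatter is therefore expected in this assay and the estimated step is a number no higher from compound 3 to compound 4 (the limit leaves the size open). Compound 4 is expected at 20000 nM with an estimated range from 8000 nM to 40000 nM.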

Compound 4, half-maximal inhibitory concentration: > 20000 nM
Compound 4: only a limit was reported (the forecaster's own chance of this, stated with the estimate: 70%); the middle value lies on the limit itself.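

With methylamino held fixed, phenyl also separates from furan-2-yl in this assay: an at least 4.0-fold higher number from compound 2 to compound 4 (0.60 log units; beyond the scatter). Among the groups shown at this carbon, furan-2-yl alone now gives a number rather than a limit, and the series collects at one ceiling: the limit of > 20000 nM in this assay, at which 3 of the 4 values shown sit. The steps from compound 3 to compound 4 and from compound 1 to compound 4 join two limits and cannot be read.

Any order among compound 1, compound 3 and compound 4 stays hidden behind those limits. From the compounds shown here alone, whether a numerical value returns with a pyridyl ring or an oxazolyl ring on this carbon remains open.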